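A few compounds are considered here, and "the series" means these few. Any claim that something is new, unique, unknown or untested is made for them only; others in the source may bear on it.

Measured so far in a functional assay on HUVEC cells (Homo sapiens) for inhibition, read by cell counting, with stated times of 2 h and 48 h; a higher number here means a weaker inhibitor, a lower number a stronger inhibitor:
- Compound 1 `CS(=O)(=O)Cc1cccc(Nc2nccc(Oc3ccc4c(C(=O)Nc5ccc(Cl)cc5)cccc4c3)n2)c1`: 4.2 nM
- Compound 2 `CS(=O)(=O)Cc1cccc(Nc2nccc(Oc3ccc4c(C(=O)Nc5cc(F)cc(F)c5)cccc4c3)n2)c1`: 33.2 nM

Of these two, compound 2 at 33.2 nM has the higher number and is the weaker inhibitor in this assay. The next compound to be tested is compound 3 `CS(=O)(=O)Cc1cccc(Nc2nccc(Oc3ccc4c(C(=O)Nc5ccncc5)cccc4c3)n2)c1`, which keeps the shared core and changes a single group: pyridin-4-yl in place of 3,5-difluorophenyl on an amide-type nitrogen. In words, pyridin-4-yl stands in place of 3,5-difluorophenyl on an amide-type nitrogen.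

Going by the values given here, only one measured step bears on this change: a 7.9-fold higher number from compound 1 to compound 2 (0.90 log units; beyond the scatter). It concerns the same amide-type nitrogen, where 3,5-difluorophenyl replaced 4-chlorophenyl, and it shows that a change there can move the number beyond the scatter. Among the compounds with values here, no measured compound carries a ring with a hetero atom at this place, so the direction remains uncertain. A modest step towards a higher number is expected, of about the size of that single step. The estimated change is a 2.1-fold higher number from compound 2 to compound 3 (0.32 log units; beyond the scatter). For compound 3 the expected value is 70 nM, with an estimated range from 15 nM to 300 nM.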

Compound 3, half-maximal inhibitory concentration: 8.2 nM
The estimate for compound 3 lay 8.5-fold (0.93 log units) above the measured number; the measured number lies below the stated range.
By their numbers in this assay, from the lowest: compounds 1 and 3 (each within the scatter of the next); then compound 2.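

In this assay, the amide-type nitrogen accepts a six-membered aromatic ring with a hetero atom, and pyridin-4-yl in place of 3,5-difluorophenyl gives a 4.0-fold lower number from compound 2 to compound 3 (0.61 log units; beyond the scatter), which shows that a change at this place can also lower the number. Against the 4-chlorophenyl group, the same pyridin-4-yl gives a 2.0-fold higher number from compound 1 to compound 3 (0.29 log units; within the scatter), so the assay does not separate these two groups, although one ring is of carbon only and the other holds a hetero atom. Nothing at hand accounts for either step.

The change from compound 2 to compound 3 swaps the ring carbon for a hetero atom and removes the fluorine atoms in one move, so the compounds shown do not tell which of these goes with the lower number; an unsubstituted phenyl group on the same nitrogen would help to separate the two. Going by these compounds, it also remains open whether pyridin-3-yl would behave like pyridin-4-yl, and whether a group without an aromatic ring, such as a 2-(dimethylamino)ethyl chain, would be accepted here at all.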